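Swapping nitro for bromo where every value sits at a limit

A few compounds are considered here, and "the series" means these few. Any claim that something is new, unique, unknown or untested is made for them only; others in the source may bear on it.

Of the compounds shown here, three built on a shared core have been measured so far. Compound 1 `O=C(Oc1ccc(Cl)cc1C(=O)Nc1ccc(Cl)c(Cl)c1)c1ccc(Br)cc1` carries a bromo group on one of its outer rings. In an ADME assay on HepG2 cells (Homo sapiens) for cytotoxicity, read by MTT assay, with a stated time of 72 h (a lower number here means a stronger inhibitor, a higher number a weaker inhibitor), compound 1 gives > 50000 nM, which is a limit of the assay rather than a number. Compound 2 `Cc1ccc(C(=O)Oc2ccc(Cl)cc2C(=O)Nc2ccc(C(F)(F)F)cc2)cc1` carries a methyl group in that position instead. In this assay compound 2 gives > 50000 nM, again a limit. Compound 3 `O=C(Oc1ccc(Cl)cc1C(=O)Nc1ccc(C(F)(F)F)cc1)c1ccc([N+](=O)[O-])cc1` carries a nitro group there. In this assay compound 3 gives > 50000 nM, also a limit. Among the measured compounds shown here, the only single-point step among them, a step that the two limits leave unreadable from compound 2 to compound 3, cannot be read because the limit of > 50000 nM in this assay, at which 3 of the 3 values shown sit, hides both ends. So compound 3 stands where the other two stand: at a limit, with no readable number.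

Compound 4 `O=C(Oc1ccc(Cl)cc1C(=O)Nc1ccc(C(F)(F)F)cc1)c1ccc(Br)cc1` differs from compound 3 by bromo in place of nitro on an aromatic carbon. For the measured compounds named here, compound 1 already shows a bromo group at this position and sits at the limit, and the one measured step touching this ring is unreadable, so no shift beyond the scatter is expected. Compound 4 is therefore expected to give 50000 nM, between 20000 nM and 120000 nM, most likely reported once more as a limit. The expected step is a number no higher from compound 3 to compound 4 (the limit leaves the size open).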

Compound 4, half-maximal inhibitory concentration: > 50000 nM
Compound 4 was reported as a limit (the forecaster's own chance of this, stated with the estimate: 85%); the middle value lies on the limit itself.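

No new step can be read: the steps to compound 4 from compound 1, compound 2 and compound 3 all have both ends hidden, because each value is a limit and not a number: the limit of > 50000 nM in this assay, at which 4 of the 4 values shown sit.

The compounds shown leave open whether any of these changes shifts the true value in this assay at all.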